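The source may hold more compounds than are shown below. What is called first, only, known or untested is meant among the compounds shown, and "the series" means these compounds.

The measured compounds:
compound 1 `O=C(Nc1ccc(-n2ncc3c(Br)cccc32)cc1)Nc1ccc(Cl)c(C(F)(F)F)c1`: 2000 nM in a functional assay on HepG2 cells (Homo sapiens) for cytotoxicity, read by MTT assay, with a stated time of 72 h; a lower number here means a stronger inhibitor, a higher number a weaker inhibitor
compound 2 `O=C(Nc1ccc(-n2ncc3c(F)cccc32)cc1)Nc1ccc(Cl)c(C(F)(F)F)c1`: 29500 nM in this assay
compound 3 `O=C(Nc1ccc(-n2ncc3ccccc32)cc1)Nc1ccc(Cl)c(C(F)(F)F)c1`: 8000 nM in this assay

Compound 1 gives the lowest number of the three in this assay; compound 3 lies nearest to it and compound 2 furthest, and both gaps stand beyond the scatter. Compound 4 `COc1cccc2c1cnn2-c1ccc(NC(=O)Nc2ccc(Cl)c(C(F)(F)F)c2)cc1` differs from compound 1 in one place: methoxy in place of bromo on an aromatic carbon. For the measured compounds named here, two measured steps bear on this change, since each of them also takes away the bromo of compound 1. The step of a 15-fold higher number from compound 1 to compound 2 (1.17 log units; beyond the scatter) is large, and the step of a 4.0-fold higher number from compound 1 to compound 3 (0.60 log units; beyond the scatter) is modest; between their two products the step of a 3.7-fold lower number from compound 2 to compound 3 (0.57 log units; beyond the scatter) is modest as well. Both known replacements of the bromo gave a higher number, so a move in that direction is expected for compound 4 too, though a methoxy was not among the groups tested and the size of the move cannot be read off closely. A step of about a 3.5-fold higher number from compound 1 to compound 4 (0.54 log units; beyond the scatter) is expected. Compound 4 is therefore estimated at 7000 nM in this assay, within a range from 2000 nM to 25000 nM.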

Compound 4, half-maximal inhibitory concentration: 4000 nM
Estimate against measurement, compound 4: 1.8-fold (0.24 log units) above, and the stated range covers the measured number.
By their numbers in this assay, from the lowest: compounds 1, 4 and 3 (each within the scatter of the next, the first and the last beyond it); then compound 2.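

In this assay, methoxy, with two heavy atoms and one hydrogen-bond acceptor where bromo has one heavy atom and none, cannot be told apart from either bromo or hydrogen at this aromatic carbon: the change shows a 2.0-fold higher number from compound 1 to compound 4 (0.30 log units; within the scatter) against bromo and a 2.0-fold lower number from compound 3 to compound 4 (0.30 log units; within the scatter) against hydrogen. Compound 4 thus sits within the scatter of both compound 1 and compound 3, although those two lie beyond the scatter of each other, and the larger methoxy group leaves the number in that same region. Fluoro alone stands apart among the four groups, as a 7.4-fold lower number from compound 2 to compound 4 (0.87 log units; beyond the scatter) shows, so the high number of compound 2 does not follow from replacing bromo as such, and no measurement offered here explains this difference.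

On these data alone, it remains open whether an amine, a hydroxyl or a longer chain such as ethoxy on this carbon would stay in the same region or move towards compound 2. Also open, as far as these compounds go, is whether the same order of groups would hold on the other carbons of this six-membered ring.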